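The source may report more compounds than this note shows. Statements on the series, on what has been measured and on what is new or still open speak of the compounds shown alone.

Measured compounds:
Compound 1, `COc1ncnc2c1c(-c1ccoc1)cn2[C@@H]1O[C@H](CO)[C@@H](O)[C@H]1O`: 110 nM
Compound 2, `C#Cc1cn([C@@H]2O[C@H](CO)[C@@H](O)[C@H]2O)c2ncnc(N(C)C)c12`: 180 nM

In a functional assay on HCT-116 cells (Homo sapiens), read by MTT assay, with a stated time of 72 h (a lower number here means a stronger inhibitor, a higher number a weaker inhibitor), compound 1 gives 110 nM and compound 2 gives 180 nM. Compound 2 carries the higher of the two numbers, and compound 1 is its nearest neighbour, lying within the scatter of it; the two values therefore cannot be ordered against each other. Going by the values given here, no step between measured compounds that differ in one place has been recorded, so no counted step is available to lean on.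

The next compound, compound 3, `C#Cc1cn([C@@H]2O[C@H](CO)[C@@H](O)[C@H]2O)c2ncnc(OC)c12`, differs from compound 2 in a single respect: methoxy in place of dimethylamino on an aromatic carbon. Compound 1 also carries a methoxy at this position of the shared core, and its value in this assay sits close to that of compound 2. On that basis the step from compound 2 to compound 3 is expected to be small, with no direction that goes beyond the scatter, and a 1.4-fold lower number from compound 2 to compound 3 (0.14 log units; within the scatter) is the estimated size. Compound 3 is accordingly expected to give about 130 nM in this assay, with a likely range from 50 nM to 350 nM.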

Compound 3, half-maximal inhibitory concentration: 4060 nM
Estimate against measurement, compound 3: 31-fold (1.49 log units) below; measured number above the stated range.
By their numbers in this assay, from the lowest: compounds 1 and 2 (each within the scatter of the next); then compound 3.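

In this assay, a methoxy group on the aromatic carbon of the shared core does not by itself go with a low number: with ethynyl kept in place, methoxy in place of dimethylamino gives a 23-fold higher number from compound 2 to compound 3 (1.35 log units; beyond the scatter). The other substituent matters as well, since with methoxy kept in place, ethynyl in place of furan-3-yl gives a 37-fold higher number from compound 1 to compound 3 (1.57 log units; beyond the scatter), so among these three compounds, the pairing of methoxy with ethynyl in compound 3 is the one that stands apart, and the closeness of the numbers for the two earlier compounds had not shown this. Nothing available here explains either step.

The compounds shown leave open whether the large step belongs to dimethylamino in particular or would also appear with another group at this position, such as a plain amino group, a methylamino group or an ethoxy group. They also leave open how dimethylamino behaves alongside furan-3-yl, and so whether the two substituents that go with the lower numbers would add to each other or make no difference together.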